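A few compounds are considered here, and "the series" means these few. Any claim that something is new, unique, unknown or untested is made for them only; others in the source may bear on it.

For the measured compounds named here, in a physicochemical assay for solubility, read by nephelometry, measured as kinetic solubility, with a stated time of 30 min, at pH 2.0 (a lower number here means a less soluble compound, a higher number a more soluble compound), compound 1 `O=C(O)COc1ccc([C@H]2CC[C@]3(CC2)OOC2(O3)C3CC4CC2CC(C3)C4O)cc1` gives 25 ug/mL, the only exact number so far. Compound 2 `O=C(O)CNC(=O)COc1ccc([C@H]2CC[C@]3(CC2)OOC2(O3)C3CC4CC(C3)CC2C4)cc1` reads < 3.1 ug/mL, which is a limit of the assay and not a number. Compound 3 `O=C(O)c1cccc([C@H]2CC[C@]3(CC2)OOC2(O3)C3CC4CC(C3)CC2C4)c1` reads < 1.6 ug/mL, which is also a limit. Compound 2 therefore has no exact position on the scale.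

Compound 4 `CCOC(=O)COc1ccc([C@H]2CC[C@]3(CC2)OOC2(O3)C3CC4CC(C3)CC2C4)cc1` carries ethoxy in place of the (carboxymethyl)amino of compound 2 on a carbonyl carbon: ethoxy in place of (carboxymethyl)amino on a carbonyl carbon. Going by the values given here, no measured pair shows this change directly. In this assay, the expected change is a step that the limit leaves unreadable from compound 2 to compound 4, with no shift beyond the usual scatter. This expectation rests on compound 2, whose reading of < 3.1 ug/mL is a limit. For compound 4 the estimated value is 2 ug/mL, with an expected range of 0.8 ug/mL to 6 ug/mL.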

Compound 4, solubility: < 0.78 ug/mL
Compound 4 was reported as a limit; the forecaster's own chance of this, stated with the estimate: 80%; at least 2.5-fold (0.40 log units) between middle value and limit.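

In this assay, for the compounds shown here, compound 2 and compound 4 both read as limits, not numbers, and no step between them can be read. The compounds shown leave open what ethoxy in place of (carboxymethyl)amino does to solubility.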